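A few compounds are considered here, and "the series" means these few. Any claim that something is new, unique, unknown or untested is made for them only; others in the source may bear on it.

Among the measured compounds shown here, compound 1 `CSc1ccc(C)cc1NCC1=NCCN1` gives 96% in a functional assay for agonist activity at Alpha-1B adrenergic receptor (Homo sapiens) (on this read-out higher numbers stand for larger maximal responses and lower numbers for smaller maximal responses), the larger of the two numbers so far, while compound 2 `Cc1ccc(S(C)(=O)=O)c(NCC2=NCCN2)c1` gives 91%; the step of a number 5 percentage points lower from compound 1 to compound 2 (within the scatter) lies within the scatter. Compound 3 `CSc1ccc(C(F)(F)F)cc1NCC1=NCCN1` differs from compound 1 by trifluoromethyl in place of methyl on an aromatic carbon. For the measured compounds named here, no measured step touches this position, and the one measured step, a number 5 percentage points lower from compound 1 to compound 2 (within the scatter), stayed within the scatter, so in this assay no change beyond the scatter is expected. For compound 3 the estimate is 95%, between 80% and 105%, an expected step of a number 1 percentage points lower from compound 1 to compound 3 (within the scatter).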

Compound 3, largest response reached (reported as maximum), in percent of the reference or control that the assay uses: 114%
Compound 3: middle estimate off by 19 percentage points, on the low side; measured number above the stated range.
By their numbers in this assay, from the lowest: compounds 2 and 1 (each within the scatter of the next); then compound 3.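

Among the compounds shown here, the carbon para to a methylsulfanyl group, which no earlier compound varied, proves sensitive in this assay: trifluoromethyl in place of methyl gives a number 18 percentage points higher from compound 1 to compound 3 (beyond the scatter) and so the first step beyond the scatter in this set. Compound 3 thus stands apart from compounds 1 and 2, which lie within the scatter of each other. Nothing available explains this rise.

From the compounds shown here alone, whether a chlorine atom, a methoxy group or an amine at this carbon would give a similar step remains open. So does whether trifluoromethyl would have the same effect alongside methylsulfonyl.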